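Swapping the hydroxylated ring on a sulfonyl sulfur

The source may report more compounds than this note shows. Statements on the series, on what has been measured and on what is new or still open speak of the compounds shown alone.

In an ADME assay on CHO cells (Cricetulus griseus) for cytotoxicity, read by MTT assay (on this read-out higher numbers stand for weaker inhibition and lower numbers for stronger inhibition), compound 1 (`O=S(=O)(NCCN1CCCC1)c1cccc(-c2ccc3nccc(-c4ccnc(C(F)(F)F)c4)c3n2)c1`) gives 13000 nM, compound 2 (`O=S(=O)(c1cccc(-c2ccc3nccc(-c4ccncc4)c3n2)c1)N1CCC(O)CC1`) gives 8000 nM and compound 3 (`O=S(=O)(NCCO)c1cccc(Nc2ccc3nccc(-c4ccncc4)c3n2)c1`) gives 4000 nM. Compound 2 therefore stands within the usual scatter of both other compounds. Compound 4 (`O=S(=O)(c1cccc(-c2ccc3nccc(-c4ccncc4)c3n2)c1)N1CC[C@H](O)C1`) carries 3-hydroxypyrrolidin-1-yl in place of 4-hydroxypiperidin-1-yl on a sulfonyl sulfur. Among the measured compounds shown here, no measured pair of compounds shows a change of this kind, so the data offer no direct guide to its size. In this assay, the expected step of no change at the digits printed from compound 2 to compound 4 (within the scatter) stays within the scatter, with no direction favoured. Compound 4 is therefore estimated at 8000 nM, with an expected range of 3500 nM to 18000 nM.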

Compound 4, half-maximal inhibitory concentration: 9000 nM
Compound 4: the middle estimate sits 1.1-fold (0.05 log units) below what was measured; the range from low to high includes it.
By their numbers in this assay, from the lowest: compounds 3, 2, 4 and 1 (each within the scatter of the next, the first and the last beyond it).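

Among the compounds shown here, this is the first pair that differs in one place, and in this assay it gives a 1.1-fold higher number from compound 2 to compound 4 (0.05 log units; within the scatter), the step from 4-hydroxypiperidin-1-yl to 3-hydroxypyrrolidin-1-yl on a sulfonyl sulfur. At this position, then, the ring can be exchanged for the smaller one carrying a defined stereocentre without leaving the scatter. Nothing given here accounts for this result. Going by these compounds, the opposite stereoisomer of compound 4 remains open. So does whether a morpholine ring or 4-aminopiperidin-1-yl on the same sulfur would also stay within the scatter of compound 2.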